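A few compounds are considered here, and "the series" means these few. Any claim that something is new, unique, unknown or untested is made for them only; others in the source may bear on it.

Three measured compounds and one unmeasured one make up this small set. Compound 1 `COc1ccc(-c2ccccc2)c(OC)c1` gives 55.2 ug/mL in a functional assay on HT-29 cells (Homo sapiens) for cytotoxicity, read by MTT assay, with a stated time of 3 days; on this read-out higher numbers stand for weaker inhibition and lower numbers for stronger inhibition. Compound 2 `COc1ccc(-c2ccccc2O)c(OC)c1` gives 33.7 ug/mL in this assay after the change (hydroxy in place of hydrogen on an aromatic carbon), a step of a 1.6-fold lower number from compound 1 to compound 2 (0.21 log units; within the scatter). Compound 3 `COc1ccc(-c2ccccc2)cc1OC` gives 41 ug/mL in this assay; the difference between the core of compound 1 and the core of compound 3 is not broken down here, and the two values lie within the scatter of each other. Compound 4 `COc1ccc(-c2cccc(O)c2)cc1OC` is unmeasured and differs from compound 3 by hydroxy in place of hydrogen on an aromatic carbon, the same kind of change as from compound 1 to compound 2 but not the same: there the hydroxy sits ortho to a large group, here meta to a large group. Among the compounds with values here, the expectation in this assay is a 1.4-fold lower number from compound 3 to compound 4 (0.14 log units; within the scatter), resting on the single earlier step of a 1.6-fold lower number from compound 1 to compound 2 (0.21 log units; within the scatter), itself within the scatter. Compound 4 is therefore estimated at 30 ug/mL, with a range from 15 ug/mL to 60 ug/mL in this assay.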

Compound 4, half-maximal inhibitory concentration: 29 ug/mL
Compound 4: the middle estimate sits 1.0-fold (0.01 log units) above what was measured; measured number inside the range.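

In this assay, hydroxy in place of hydrogen on an aromatic carbon gives a 1.4-fold lower number from compound 3 to compound 4 (0.15 log units; within the scatter), and this step agrees with the earlier one on the other core: the same change on two cores in this assay, a 1.6-fold lower number (0.21 log units; within the scatter) from compound 1 to compound 2 and a 1.4-fold lower number (0.15 log units; within the scatter) from compound 3 to compound 4, 1.2-fold (0.06 log units) apart, within the scatter of two such steps. The pair shows that the change carries across these two cores without a detectable difference, but each step lies within the scatter, so it does not show that hydroxy lowers the number on either core. The hydroxy in compound 4 is meta to a large group, and it sits differently in compound 2, so the effects of core and position are not separated.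

Going by these compounds, it remains open whether an amine or a carboxylic acid in place of the hydroxy on the core of compound 3 would give a step beyond the scatter. Also open is how any of these compounds would behave in other cell lines.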